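This account rests on a few compounds, and the source may have more. Where it says the series, first, only, none or still open, it means among the compounds named here.

Measured compounds so far:

Compound 1, `COc1c(N2CCCC(N)C2)c(F)cc2c(=O)c(C(=O)O)cn(C3CC3)c12`: in a functional assay on V79 cells (Cricetulus griseus) for cytotoxicity, read by colony formation (a lower number here means a stronger inhibitor, a higher number a weaker inhibitor), compound 1 gives 69 ug/mL.
Compound 2, `NC1CCCN(c2c(F)cc3c(=O)c(C(=O)O)cn(C4CC4)c3c2C(F)(F)F)C1`: compound 2 gives only > 500 ug/mL, which is a limit of the assay and not a number.
Compound 3, `COc1c(N2CCC(C)(N)C2)c(F)cc2c(=O)c(C(=O)O)cn(C3CC3)c12`: in this assay compound 3 gives 38 ug/mL.

Compound 3 and compound 1 sit close to each other, the step being a 1.8-fold lower number from compound 1 to compound 3 (0.26 log units; within the scatter), so no order between them is claimed. Compound 2 against compound 1 is a different matter: the step is an at least 7.2-fold higher number from compound 1 to compound 2 (0.86 log units; beyond the scatter), and the value of compound 2 is a limit, as the limit of > 500 ug/mL in this assay, at which 1 of the 3 values shown sits, records.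

Compound 4, `CC1(N)CCN(c2c(F)cc3c(=O)c(C(=O)O)cn(C4CC4)c3c2C(F)(F)F)C1`, has not yet been measured. It differs from compound 3 by trifluoromethyl in place of methoxy on an aromatic carbon. This is the same kind of change as from compound 1 to compound 2 (trifluoromethyl in place of methoxy on an aromatic carbon), though not the same: there the place is ortho to a 3-aminopiperidin-1-yl group, here it is ortho to a 3-amino-3-methylpyrrolidin-1-yl group. The two cores differ by 3-amino-3-methylpyrrolidin-1-yl in place of 3-aminopiperidin-1-yl on an aromatic carbon.

Among the compounds with values here, only one earlier instance of the change exists, and it ended at a limit. The expectation for compound 4 in this assay is a step of an 11-fold higher number from compound 3 to compound 4 (1.02 log units; beyond the scatter), set beside the earlier step of an at least 7.2-fold higher number from compound 1 to compound 2 (0.86 log units; beyond the scatter), and it rests on that single pair, with compound 2 having returned only a limit. Compound 4 is therefore estimated at about 400 ug/mL, within a range from 150 ug/mL to 1500 ug/mL, and it may itself come back only as a limit.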

Compound 4, half-maximal inhibitory concentration: 110 ug/mL
Compound 4: middle estimate off by 3.6-fold (0.56 log units), on the high side, and the stated range ends above it.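

In this assay, trifluoromethyl in place of methoxy goes the same way on both cores shown, and on the core of compound 3 it gives a measured step, a 2.9-fold higher number from compound 3 to compound 4 (0.46 log units; beyond the scatter), which shows that the direction carries over between these two cores but not that it would hold on any third one. The size of the step cannot be said to carry over or to differ: the same change on two cores in this assay, an at least 7.2-fold higher number (0.86 log units; beyond the scatter) from compound 1 to compound 2 and a 2.9-fold higher number (0.46 log units; beyond the scatter) from compound 3 to compound 4; the limit leaves it open whether they differ. With trifluoromethyl held in place, 3-amino-3-methylpyrrolidin-1-yl in place of 3-aminopiperidin-1-yl gives an at least 4.5-fold lower number from compound 2 to compound 4 (0.65 log units; beyond the scatter), yet this does not establish that the effect of that ring swap depends on the neighbouring group: the same change on two cores in this assay, a 1.8-fold lower number (0.26 log units; within the scatter) from compound 1 to compound 3 and an at least 4.5-fold lower number (0.65 log units; beyond the scatter) from compound 2 to compound 4; the limit leaves it open whether they differ.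

Going by these compounds, compound 2 gives > 500 ug/mL, which is a limit of the assay and not a number, so the true size of each step that involves it stays open. Also open, on these data alone, is how other groups on that aromatic carbon, such as a nitrile or an ethoxy group, would compare with methoxy and trifluoromethyl on either core.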